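Nitro on the Benzyl Ring of a Crown-Fused Series

This account rests on a few compounds, and the source may have more. Where it says the series, first, only, none or still open, it means among the compounds named here.

Compound 1 `c1ccc(COc2ccccc2Nc2ncnc3cc4c(cc23)OCCOCCO4)cc1` has been tested in a functional assay on HepG2 cells (Homo sapiens) for antiproliferative activity, read by MTT assay, with a stated time of 72 h (a lower number here means a stronger inhibitor, a higher number a weaker inhibitor), and gives > 100000 nM, which is a limit of the assay rather than a number. Compound 2 `FC(F)(F)c1ccc(COc2cccc(Nc3ncnc4cc5c(cc34)OCCOCCO5)c2)cc1` gives > 100000 nM in this assay, again a limit. Compound 3 `O=[N+]([O-])c1ccc(COc2ccc(Nc3ncnc4cc5c(cc34)OCCOCCOCCOCCO5)cc2)cc1` gives > 100000 nM in this assay, also a limit. On the numbers shown, compound 1 therefore stands nowhere distinct: every measured compound sits at the limit of > 100000 nM in this assay, at which 3 of the 3 values shown sit, and no ordering among the three can be read. Within the data shown here, no two measured compounds differ in only one place, so no measured step is available and the size of any change in this assay has to be guessed from the shared limit alone.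

Compound 4 `O=[N+]([O-])c1ccc(COc2ccccc2Nc2ncnc3cc4c(cc23)OCCOCCO4)cc1` differs from compound 1 by nitro in place of hydrogen on an aromatic carbon of the benzyl ring, or phenyl to 4-nitrophenyl. Compound 3 also carries a (4-nitrobenzyl)oxy group and reaches only the limit. For this assay no step beyond the scatter is expected in either direction. The expected step that the limit leaves unreadable from compound 1 to compound 4 is estimated as none beyond the scatter. Compound 4 is expected to give 150000 nM, with a range from 40000 nM to 600000 nM, most likely reported again as a limit.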

Compound 4, half-maximal inhibitory concentration: 50200 nM
Estimate against measurement, compound 4: 3.0-fold (0.48 log units) above; the measured number falls inside the stated range.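

Nitro in place of hydrogen on an aromatic carbon of the benzyl ring, para to a large group, gives the first value of the series in this assay that is a number and not a limit, and the change is read as an at least 1.9-fold lower number from compound 1 to compound 4 (0.29 log units; that floor lies within the scatter) with nothing beyond that floor to be claimed for it. The (4-nitrobenzyl)oxy group does not bring a number in every compound shown, since compound 3 also carries it and its > 100000 nM is a limit. The full size of the step cannot be read, because compound 1 sits at the limit of the assay: the limit of > 100000 nM in this assay, at which 3 of the 4 values shown sit.

From the compounds shown here alone, whether this position answers to nitro in particular stays open, since an amine, a nitrile or a carboxylic acid in the same place would be needed to tell that in this assay. Also open, going by these compounds, is whether nitro in place of the trifluoromethyl of compound 2 would give a number on that compound's otherwise unchanged structure.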